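This account rests on a few compounds, and the source may have more. Where it says the series, first, only, none or still open, it means among the compounds named here.

Measured in a functional assay on the whole organism for inhibition, with Cavia porcellus as the target; on this read-out higher numbers stand for an effect only at larger amounts of compound and lower numbers for an effect already at smaller amounts:

compound 1, `COc1ccccc1OCC1SCCN1C(=O)CSC(C)=O`, gives 26 mg/kg
compound 2, `CC(=O)SCC(=O)N1CCSC1CCc1ccccc1O`, gives 61 mg/kg
compound 3, `COc1ccccc1OC[C@@H]1SCCN1C(=O)CSC(C)=O`, gives 52 mg/kg

Compound 3 stands second highest of the three numbers in this assay. It lies closest to compound 2 and furthest from compound 1, but both of those gaps are within the scatter, so no order among the three can be read from them.

Compound 4, `COc1ccccc1OC[C@H]1SCCN1C(=O)CSC(C)=O`, has not yet been measured. Set against compound 3, (the two compounds have the same atoms and bonds and differ only in configuration as drawn: 1 of 1 stereo elements differ; a stereocentre at a saturated ring carbon is drawn S in compound 3 and R in compound 4).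

Within the data shown here, only one measured step speaks to a change at this stereocentre: a 2.0-fold higher number from compound 1 to compound 3 (0.30 log units; within the scatter). What sets those two compounds apart is the fact that one of compounds 1 and 3 is drawn with a defined configuration and the other without, at the place where they differ. If compound 1 holds both configurations and compound 3 only one of them, then the other configuration, which is compound 4, could account for the number of compound 1 being the lower of the two, but the step itself does not exceed the scatter, so this is at most a weak pointer.

On that basis the step of a 2.4-fold lower number from compound 3 to compound 4 (0.37 log units; beyond the scatter) is expected to run toward a lower number, though not far. Compound 4 is therefore estimated at 22 mg/kg in this assay. The range for compound 4 is expected to span from 8 mg/kg to 60 mg/kg.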

Compound 4, dose for half-maximal effect: 48 mg/kg
For compound 4 the middle estimate is 2.2-fold (0.34 log units) below the measured one; the measured number falls inside the stated range.
By their numbers in this assay, from the lowest: compounds 1, 4, 3 and 2 (each within the scatter of the next, the first and the last beyond it).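

In this assay, among these compounds, the change of configuration at the saturated ring carbon gives a 1.1-fold lower number from compound 3 to compound 4 (0.03 log units; within the scatter), which places the two drawn configurations side by side for the first time and shows that this read-out does not separate them. Set against the form drawn without a configuration, the R form shows a 1.8-fold higher number from compound 1 to compound 4 (0.27 log units; within the scatter), and this step stays within the scatter, as does the step for the S form, a 2.0-fold higher number from compound 1 to compound 3 (0.30 log units; within the scatter). With atoms and bonds held fixed, the comparison isolates this stereocentre and gives no sign that either configuration carries more of the effect at this position: the fact that compounds 3 and 4 differ only in the configuration as drawn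

On these data alone, it remains open whether the configuration at this carbon would still make no readable difference with a carboxylic acid or an amine in place of the methoxy group, or with a longer chain in place of the one that joins that part of the molecule to the shared core. Nor does this assay show whether the two configurations would also stay together in a measurement made outside the whole organism.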